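The source may hold more compounds than are shown below. What is called first, only, known or untested is meant among the compounds shown, and "the series" means these compounds.

Compound 1 `CC1=C(C(=O)Nc2ccc(F)cc2)C(c2ccc([N+](=O)[O-])cc2)N=C(SCc2ccccc2)N1` in a functional assay on the whole organism (artery, strain albino) with Rattus norvegicus as the target, with a stated time of 60 min, at a dose of 10 mg/kg by the oral route (a higher number here means more inhibition at the dose given (going by the name of the read-out), a lower number less inhibition), gives 12.3%. Compound 2 `CC1=C(C(=O)Nc2ccc(F)cc2)C(c2ccc([N+](=O)[O-])cc2)N=C(SCc2ccccc2Cl)N1` carries chloro in place of hydrogen on an aromatic carbon on the core of compound 1; in this assay compound 2 gives 6.2%, the step being a number 6.1 percentage points lower from compound 1 to compound 2 (within the scatter). Compound 3 `CC1=C(C(=O)Nc2ccc(Br)cc2)C(c2ccc(Cl)cc2Cl)N=C(SCc2ccccc2)N1` has a different core, and the difference between the two cores is not broken down here; in this assay compound 3 gives 6.7%. Compound 4 `CC1=C(C(=O)Nc2ccc(Br)cc2)C(c2ccc(Cl)cc2Cl)N=C(SCc2ccccc2Cl)N1` stands to compound 3 as compound 2 stands to compound 1, with chloro in place of hydrogen on an aromatic carbon, the same change at the same place. Going by the values given here, since the one measured instance of this change gave a number 6.1 percentage points lower from compound 1 to compound 2 (within the scatter), a small step of similar size is expected, namely a number 3.7 percentage points lower from compound 3 to compound 4 (within the scatter), although this rests on a single pair. Compound 4 is therefore estimated to give 3% in this assay, between -6% and 12%.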

Compound 4, a percentage reported as inhibition, in the whole organism at one dose (the size of the read-out at that dose, not a potency): 11.8%
For compound 4 the middle estimate is 8.8 percentage points below the measured one; the range from low to high includes it.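

In this assay, the change from benzyl to 2-chlorobenzyl on the core of compound 3 is a step of a number 5.1 percentage points higher from compound 3 to compound 4 (within the scatter). Set beside the earlier pair, the two steps do not differ by more than repeat measurements would: the same change on two cores in this assay, a number 6.1 percentage points lower (within the scatter) from compound 1 to compound 2 and a number 5.1 percentage points higher (within the scatter) from compound 3 to compound 4, 11.2 percentage points apart, within the scatter of two such steps. This gives no sign that the change behaves differently on the two cores and no sign of a real effect on either, but two small steps do not show that the change carries over unaltered, and a modest difference between cores could remain unseen.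

The compounds shown leave open whether an amine or a carboxylic acid in place of chloro on the benzyl ring would shift the inhibition beyond the scatter. They also leave open what a longer chain in place of benzylsulfanyl would do.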